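The compounds below may be only part of what the source reports. "The series", "measured", "known", "first", "only" and "open" are said of these compounds alone.

Three compounds have been measured in a functional assay on A498 cells (Homo sapiens) for inhibition, read by sulforhodamine B assay, with a stated time of 48 h, tested at 10 uM; a higher number here means more inhibition at the concentration tested (going by the name of the read-out), a lower number less inhibition:

compound 1 `O=Cc1ccc(-c2cn3ccnc3c(-c3ccc4ncn(C5CCCCC5)c4c3)n2)cc1` gives 11.2%;
compound 2 `c1ccc2c(-c3cn4ccnc4c(-c4ccc5ncn(C6CCCCC6)c5c4)n3)cccc2c1` gives 14%;
compound 3 `c1cn2cc(-c3ccsc3)nc(-c3ccc4ncn(C5CCCCC5)c4c3)c2n1` gives 20.1%.

Among these three numbers compound 1 stands lowest. The nearest is compound 2, separated by a number 2.8 percentage points higher from compound 1 to compound 2 (within the scatter), and the furthest is compound 3, separated by a number 8.9 percentage points higher from compound 1 to compound 3 (within the scatter). Both of these separations lie within the scatter, as does a number 6.1 percentage points higher from compound 2 to compound 3 (within the scatter), so the three measured compounds show no real difference from one another.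

Compound 4 `c1csc(-c2cn3ccnc3c(-c3ccc4ncn(C5CCCCC5)c4c3)n2)c1` has not yet been measured. It differs from compound 1 in one place: thiophen-2-yl in place of 4-formylphenyl on an aromatic carbon. The step bearing most closely on this change is a number 8.9 percentage points higher from compound 1 to compound 3 (within the scatter), where thiophen-3-yl replaced the same 4-formylphenyl group on the same aromatic carbon. The other two steps, a number 2.8 percentage points higher from compound 1 to compound 2 (within the scatter) and a number 6.1 percentage points higher from compound 2 to compound 3 (within the scatter), likewise show that exchanging the group at this position moved the number only within the scatter. The expected step is therefore a number 5.8 percentage points higher from compound 1 to compound 4 (within the scatter), not beyond the scatter. In this assay compound 4 is estimated at 17%, with a range from 6% to 28%.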

Compound 4, a percentage reported as inhibition, at one concentration (the size of the read-out at that concentration, not a potency): 25%
Compound 4: the middle estimate sits 8 percentage points below what was measured; low and high end bracket the measured number.
By their numbers in this assay, from the lowest: compounds 1, 2, 3 and 4 (each within the scatter of the next, the first and the last beyond it).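

In this assay, going by these compounds alone, the place on the aromatic carbon next to the ring nitrogen now shows a change beyond the scatter: thiophen-2-yl in place of 4-formylphenyl gives a number 13.8 percentage points higher from compound 1 to compound 4 (beyond the scatter), and thiophen-2-yl in place of naphthalen-1-yl gives a number 11 percentage points higher from compound 2 to compound 4 (beyond the scatter), both modest, whereas no exchange among the earlier compounds left the scatter. The two thiophene attachments cannot be told apart, since thiophen-2-yl in place of thiophen-3-yl gives a number 4.9 percentage points higher from compound 3 to compound 4 (within the scatter). Nothing available accounts for these differences.

Open, from the compounds shown here alone, is whether a five-membered aromatic ring with a different hetero atom, such as furan-2-yl, behaves like thiophen-2-yl at this place. Also open, going by these compounds, is what an amine, a carboxylic acid or a longer chain would do there, and all these readings remain single-concentration inhibition rather than potency.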